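Sulfur to Selenium Swap Across Two Cores

This account rests on a few compounds, and the source may have more. Where it says the series, first, only, none or still open, it means among the compounds named here.

Compound 1 `Cc1noc(C)c1CSC#N` and compound 2 `Cc1noc(C)c1C[Se]C#N` share one core, while compound 3 `N#CSCc1ccc(-n2cccc2)cc1` and compound 4 `N#C[Se]Cc1ccc(-n2cccc2)cc1` share another; the difference between the two cores is not broken down here. In a functional assay on PC-3 cells (Homo sapiens) for cytotoxicity, read by MTT assay, with a stated time of 72 h (a higher number here means a weaker inhibitor of growth, a lower number a stronger inhibitor of growth), compound 1 gives 8000 nM, compound 2 gives 5600 nM, and compound 3 gives 14100 nM. The numbers of compound 3 and compound 1 fall within the scatter of each other, whereas the gap between compound 3 and compound 2 lies beyond it. The change from compound 1 to compound 2 is a group of 3 heavy atoms (1 carbon, 1 nitrogen, 1 selenium; no ring) in place of a group of 3 heavy atoms (1 carbon, 1 nitrogen, 1 sulfur; no ring), on a saturated chain carbon bound to an aromatic carbon, and in this assay it produced a 1.4-fold lower number from compound 1 to compound 2 (0.15 log units; within the scatter). Compound 4 is derived from compound 3 by the same change, (a group of 3 heavy atoms (1 carbon, 1 nitrogen, 1 selenium; no ring) in place of a group of 3 heavy atoms (1 carbon, 1 nitrogen, 1 sulfur; no ring), on a saturated chain carbon bound to an aromatic carbon), at the same place. Because a 1.4-fold lower number from compound 1 to compound 2 (0.15 log units; within the scatter) stayed within the scatter, the step from compound 3 to compound 4 in this assay is expected to be of like size, a 1.4-fold lower number from compound 3 to compound 4 (0.15 log units; within the scatter). Compound 4 is therefore estimated at 10000 nM, with the likely range expected to run from 5000 nM to 20000 nM.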

Compound 4, concentration for 50% growth inhibition: 59900 nM
Compound 4: the middle estimate sits 6.0-fold (0.78 log units) below what was measured; the measured number lies above the stated range.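

In this assay the replacement of cyanosulfanyl by its selenium counterpart gave a 4.2-fold higher number from compound 3 to compound 4 (0.63 log units; beyond the scatter), which makes compound 4 a weaker inhibitor of growth than compound 3. Set beside the step on the other core, the same change did not carry over from one core to the other: the same change on two cores in this assay, a 1.4-fold lower number (0.15 log units; within the scatter) from compound 1 to compound 2 and a 4.2-fold higher number (0.63 log units; beyond the scatter) from compound 3 to compound 4, 6.1-fold (0.78 log units) apart, beyond the scatter of two such steps. This shows that, in these two pairs, a step within the scatter on the core of compound 1 was no guide to the step on the core of compound 3, but it does not show which feature of the two cores accounts for the difference, and two pairs give no rule for any further core.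

The compounds shown leave open how the same change would behave on a core bearing an amine or a carboxylic acid, or with a longer chain in place of the single saturated chain carbon. They also leave open whether the difference between the two cores would hold in other cell lines.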